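This account rests on a few compounds, and the source may have more. Where it says the series, first, only, none or still open, it means among the compounds named here.

Compound 1, `CN(c1cc2ncc(=O)[nH]c2cc1Nc1nc(-c2ccc(F)cc2)cs1)C1CCCCC1`, gives 9920 nM in this study.
Compound 2, `CN(c1cc2ncc(=O)[nH]c2cc1Nc1nc(-c2ccc(C#N)cc2)cs1)C1CCCCC1`, gives 18100 nM.
Compound 3, `CN(c1cc2ncc(=O)[nH]c2cc1Nc1nc(-c2cccc3ccccc23)cs1)C1CCCCC1`, gives 57400 nM.

All three share one core and were tested in an ADME assay on Huh-7 cells (Homo sapiens) for cytotoxicity; on this read-out higher numbers stand for weaker inhibition and lower numbers for stronger inhibition. Compound 3 holds the highest number of the three; the two steps that lead to it, a 5.8-fold higher number from compound 1 to compound 3 (0.76 log units; beyond the scatter) and a 3.2-fold higher number from compound 2 to compound 3 (0.50 log units; beyond the scatter), both lie beyond the scatter, so compound 3 is the weakest inhibitor of the set on this read-out. The step of a 1.8-fold higher number from compound 1 to compound 2 (0.26 log units; within the scatter) stays within the scatter.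

Compound 4, `CN(c1cc2ncc(=O)[nH]c2cc1Nc1nc(-c2ccc(-c3ccccc3)cc2)cs1)C1CCCCC1`, is not yet measured. It differs from compound 3 in one place: 4-phenylphenyl in place of naphthalen-1-yl on an aromatic carbon. The two steps that bear on this change, a 5.8-fold higher number from compound 1 to compound 3 (0.76 log units; beyond the scatter) and a 3.2-fold higher number from compound 2 to compound 3 (0.50 log units; beyond the scatter), each swapped a single six-membered aromatic ring for a two-ring group and each raised the number by a modest amount. Here one two-ring group replaces another of the same ring count, so no measured step matches the change directly. Compound 4 is therefore expected to stay close to compound 3, with a step of about a 1.3-fold lower number from compound 3 to compound 4 (0.11 log units; within the scatter) that need not exceed the scatter. Compound 4 is estimated at 45000 nM, with a range from 15000 nM to 120000 nM.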

Compound 4, half-maximal inhibitory concentration: 82000 nM
The estimate for compound 4 lay 1.8-fold (0.26 log units) below the measured number; measured number inside the range.
By their numbers in this assay, from the lowest: compounds 1 and 2 (each within the scatter of the next); then compounds 3 and 4 (each within the scatter of the next).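

At this position, on an aromatic carbon of the five-membered aromatic ring with one nitrogen and one sulfur, the change from naphthalen-1-yl to 4-phenylphenyl gives a 1.4-fold higher number from compound 3 to compound 4 (0.15 log units; within the scatter) in this assay, so this read-out does not separate these two groups of two six-membered aromatic rings, even though the second ring is attached differently in each. The new compound also shows that a phenyl group carried on the aromatic ring behaves differently from the smaller substituents, with a 4.5-fold higher number from compound 2 to compound 4 (0.66 log units; beyond the scatter) for phenyl in place of cyano and an 8.3-fold higher number from compound 1 to compound 4 (0.92 log units; beyond the scatter) for phenyl in place of fluoro, so among these four compounds both two-ring groups stand apart from the fluoro and cyano compounds, and none goes against this. Nothing available explains this separation or the lack of one between compound 3 and compound 4.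

The four compounds leave open whether the separation follows the second aromatic ring itself or would also appear with a non-aromatic group such as morpholine at the same place. They also leave open how an amine or a carboxylic acid on the phenyl ring of compound 4 would read in this assay.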